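The source may report more compounds than this note shows. Statements on the series, on what has been measured and on what is new or still open speak of the compounds shown alone.

Of the compounds shown here, three built on one shared core have so far been measured in a functional assay on MKN-45 cells (Homo sapiens) for inhibition, with a stated time of 72 h; on this read-out higher numbers stand for weaker inhibition and lower numbers for stronger inhibition. Compound 1 `COc1ccc(S(=O)(=O)N2CCc3cccc(-c4ccc(C#N)cc4)c32)cc1` gives 17.2 nM in this assay. Compound 2 `COc1ccc(S(=O)(=O)N2CCc3cccc(-c4ccc(F)nc4)c32)cc1` gives 145 nM, and compound 3 `COc1ccc(S(=O)(=O)N2CCc3cccc(-c4ccc(N(C)C)cc4)c32)cc1` gives 237 nM. Compound 3 therefore carries the highest number of the three, although the step of a 1.6-fold higher number from compound 2 to compound 3 (0.21 log units; within the scatter) lies within the scatter, while the step of a 14-fold higher number from compound 1 to compound 3 (1.14 log units; beyond the scatter) lies beyond it.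

Compound 4 `COc1ccc(-c2cccc3c2N(S(=O)(=O)c2ccc(OC)cc2)CC3)cc1` differs from compound 3 in a single place: methoxy in place of dimethylamino on an aromatic carbon. Among the compounds with values here, no measured pair compares methoxy with dimethylamino directly. The most relevant measured step is a 14-fold higher number from compound 1 to compound 3 (1.14 log units; beyond the scatter), which shows that swapping the group on this aromatic carbon can move the number by a large amount; the step of an 8.4-fold higher number from compound 1 to compound 2 (0.93 log units; beyond the scatter) adds that a different six-membered ring with its own substituent also gave a higher number than the cyano compound. Because the step of a 14-fold higher number from compound 1 to compound 3 (1.14 log units; beyond the scatter) is large, a group that is neither cyano nor dimethylamino is expected to land somewhere between those two compounds. For compound 4 a modest move toward a lower number is therefore expected, a 2.2-fold lower number from compound 3 to compound 4 (0.33 log units; beyond the scatter). The estimate for compound 4 in this assay is 110 nM, within a range from 35 nM to 350 nM.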

Compound 4, half-maximal inhibitory concentration: 211 nM
Estimate against measurement, compound 4: 1.9-fold (0.28 log units) below; the measured number falls inside the stated range.
By their numbers in this assay, from the lowest: compound 1; then compounds 2, 4 and 3 (each within the scatter of the next).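

In this assay, within the data shown here, the exchange of dimethylamino for methoxy on an aromatic carbon para to a large group gives a 1.1-fold lower number from compound 3 to compound 4 (0.05 log units; within the scatter), so this pair of groups cannot be told apart here, a direct comparison the earlier compounds did not offer. The 4-methoxyphenyl and 6-fluoropyridin-3-yl groups also cannot be separated, with a 1.5-fold higher number from compound 2 to compound 4 (0.16 log units; within the scatter), whereas the cyano compound stays clearly apart, with a 12-fold higher number from compound 1 to compound 4 (1.09 log units; beyond the scatter), a step of the same large kind as a 14-fold higher number from compound 1 to compound 3 (1.14 log units; beyond the scatter). Among these four compounds, three therefore form one group within the scatter and only compound 1 stands apart, but nothing available here explains that difference.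

Going by these compounds, it remains open whether the lower number belongs to the nitrile alone or would also appear with another group on this aromatic carbon, such as trifluoromethyl, a carboxylic acid or an amide. The shared core is also the same in all four compounds, so these results say nothing about how a change there would affect the number.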